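The source may hold more compounds than are shown below. What is called first, only, known or untested is meant among the compounds shown, and "the series" means these compounds.

Compound 1 `CCCc1ccc(C(=O)Nc2cccc(NC(=O)COc3ccc4c(=O)ccoc4c3)c2)cc1` and compound 2 `O=C(COc1ccc2c(=O)ccoc2c1)Nc1cccc(NC(=O)c2cnc(C(F)(F)F)s2)c1` have been measured in an assay on isolated protein for inhibition of Rho-associated protein kinase 2 (Homo sapiens), read by scintillation counting, radiometric assay and 33P incorporation, with a stated time of 40 min, in the presence of a further agent that is not named here; on this read-out lower numbers stand for stronger inhibition and higher numbers for weaker inhibition: compound 1 gives 14 nM, and compound 2 gives 10 nM.

Compound 2 shows the lowest of the two numbers, but the step of a 1.4-fold lower number from compound 1 to compound 2 (0.15 log units; within the scatter) is within the scatter, so the two compounds cannot be ordered. Compound 3 `NCc1ccc(C(=O)Nc2cccc(NC(=O)COc3ccc4c(=O)ccoc4c3)c2)cc1` differs from compound 2 by 4-(aminomethyl)phenyl in place of 2-(trifluoromethyl)-1,3-thiazol-5-yl on a carbonyl carbon. Going by the values given here, only the step from compound 1 to compound 2 bears on this position; it shows that exchanging the group on the carbonyl carbon left the number little changed. An aminomethyl group has not been tested here, so a modest loss is allowed for. Compound 3 is therefore expected to show a 3.0-fold higher number from compound 2 to compound 3 (0.48 log units; beyond the scatter), giving an estimate of 30 nM with a range of 8 nM to 120 nM.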

Compound 3, half-maximal inhibitory concentration: 66 nM
Compound 3: the middle estimate sits 2.2-fold (0.34 log units) below what was measured; low and high end bracket the measured number.
By their numbers in this assay, from the lowest: compounds 2 and 1 (each within the scatter of the next); then compound 3.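

In this assay, the group on the carbonyl carbon now makes a difference: 4-(aminomethyl)phenyl in place of 2-(trifluoromethyl)-1,3-thiazol-5-yl gives a 6.6-fold higher number from compound 2 to compound 3 (0.82 log units; beyond the scatter), whereas the earlier exchange at this position stayed within the scatter. Amino in place of ethyl on a saturated chain carbon bound to an aromatic carbon gives a 4.7-fold higher number from compound 1 to compound 3 (0.67 log units; beyond the scatter), so this single exchange on the chain is enough to raise the number. Nothing available accounts for either step. Still open, on these data alone, is how a dimethylamino group, a longer aminoalkyl chain or a carboxylic acid in that chain position would compare.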